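Acylthiourea benzazole series: cell inhibition notes

A few compounds are considered here, and "the series" means these few. Any claim that something is new, unique, unknown or untested is made for them only; others in the source may bear on it.

Measured compounds in a functional assay on HUVEC cells (Homo sapiens) for inhibition, read by colorimetric assay and crystal violet staining, with a stated time of 72 h; a higher number here means a weaker inhibitor, a lower number a stronger inhibitor:
- compound 1 `N#Cc1ccc2[nH]c(-c3cccc(NC(=S)NC(=O)c4ccc5c(c4)OCCO5)c3)nc2c1`: "not determined" (no result reported)
- compound 2 `CCOc1ccc(C(=O)NC(=S)Nc2cc(-c3nc4ccccc4[nH]3)ccc2C)cc1OCC`: 6000 nM
- compound 3 `Cc1ccc(-c2nc3ccccc3[nH]2)cc1NC(=S)NC(=O)c1ccccc1`: > 10000 nM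

Compound 1 has no number in this assay; its entry reads "not determined" (no result reported). Compound 2 in this assay gives 6000 nM. For compound 3 this assay reports only a limit, > 10000 nM, not a number. Among the three entries one sits at that limit, as the limit of > 10000 nM in this assay, at which 1 of the 3 values shown sits, states, one is a number and one is undetermined, so compound 1 stands nowhere on the numbers shown.

Compound 4 `O=C(NC(=S)Nc1cccc(-c2nc3ccccc3s2)c1)c1ccc2c(c1)OCCO2` differs from compound 1 by 1,3-benzothiazol-2-yl in place of 5-cyano-1H-benzimidazol-2-yl on an aromatic carbon. For the measured compounds named here, no measured step matches this change, so no measured size of effect is available for it. Taking compounds 2 and 3 as the only points of reference, both sit in the weak range of this assay, and compound 4 shares the acylthiourea and benzodioxine portions with compound 1, so the expectation is a weak value that may also end up as a limit. Compound 4 is expected to give 8000 nM, within 2000 nM to 30000 nM.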

Compound 4, half-maximal inhibitory concentration: 2600 nM
Estimate against measurement, compound 4: 3.1-fold (0.49 log units) above; measured number inside the range.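

In this assay compound 4 gives 2600 nM, but compound 1 offers no number to set against it, so no new step can be read between them. The compounds shown leave open what exchanging 5-cyano-1H-benzimidazol-2-yl for 1,3-benzothiazol-2-yl alone does to inhibition.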